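This account rests on a few compounds, and the source may have more. Where it says the series, first, only, none or still open, it means among the compounds named here.

Of the compounds shown here, three sharing one core have been measured in an in vitro ADME assay on microsomes from Gut (Homo sapiens) for metabolic stability, in the presence of a further agent that is not named here; on this read-out higher numbers stand for fast clearance and lower numbers for slow clearance. Compound 1 `COc1ccc(C)cc1Cn1c(C(=O)NCC(C)(C)CO)cc2cc(C#N)ccc21` gives 64 mL.min-1.g-1, compound 2 `Cc1ccc(Cl)cc1Cn1c(C(=O)NCC(C)(C)CO)cc2cc(C#N)ccc21` gives 124 mL.min-1.g-1 and compound 3 `Cc1ccc(C)c(Cn2c(C(=O)NCC(C)(C)CO)cc3cc(C#N)ccc32)c1` gives 124 mL.min-1.g-1. Compound 3 therefore stands level with compound 2 and within the scatter of compound 1.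

The next structure, compound 4 `CCCOc1cccc(Cn2c(C(=O)NCC(C)(C)CO)cc3cc(C#N)ccc32)c1`, differs from compound 3 as follows: 3-propoxyphenyl in place of 2,5-dimethylphenyl on a saturated chain carbon bound to an aromatic nitrogen. Within the data shown here, three measured steps bear on this change, and all of them stay within the scatter: a 1.9-fold higher number from compound 1 to compound 2 (0.29 log units; within the scatter), a 1.9-fold higher number from compound 1 to compound 3 (0.29 log units; within the scatter) and no change at the digits printed from compound 2 to compound 3 (within the scatter). Among the measured compounds shown here, none of the measured compounds carries a propoxy group, so these steps are only an indirect guide. On the evidence of compound 1, compound 2 and compound 3, no step beyond the scatter is expected in this assay. The expected step is a 1.1-fold lower number from compound 3 to compound 4 (0.03 log units; within the scatter). Compound 4 is estimated at 115 mL.min-1.g-1, with an expected range of 55 mL.min-1.g-1 to 240 mL.min-1.g-1.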

Compound 4, intrinsic clearance in microsomes: 45 mL.min-1.g-1
Compound 4: the middle estimate sits 2.6-fold (0.41 log units) above what was measured; measured number below the stated range.
By their numbers in this assay, from the lowest: compounds 4, 1, 2 and 3 (each within the scatter of the next, the first and the last beyond it).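

In this assay, among these compounds, the group on a saturated chain carbon bound to an aromatic nitrogen now moves the read-out beyond the scatter, which no earlier step had done: 3-propoxyphenyl gives a 2.8-fold lower number from compound 3 to compound 4 (0.44 log units; beyond the scatter) and a 2.8-fold lower number from compound 2 to compound 4 (0.44 log units; beyond the scatter). Against the 2-methoxy-5-methylphenyl group the change stays small, with a 1.4-fold lower number from compound 1 to compound 4 (0.15 log units; within the scatter), so the two compounds carrying an alkoxy group lie within the scatter of each other, although compound 1 also lies within the scatter of compound 2 and compound 3. Nothing available explains this step.

The compounds shown do not separate the effect of the propoxy chain from that of losing the groups of the 2,5-dimethylphenyl ring. As far as these compounds go, how an ethoxy group, a longer butoxy chain or an amine at the end of the chain would read also remains open.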